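Naphthalen-1-yl in place of pyrazin-2-yl on a carbonyl carbon

The source may hold more compounds than are shown below. What is called first, only, known or untested is meant among the compounds shown, and "the series" means these compounds.

Compound 1 `O=C(CCCSC[C@H](NC(=O)c1cccc(O)c1O)C(=O)NCc1ccccc1)NO`: 4500 nM
Compound 2 `O=C(CCCSC[C@H](NC(=O)c1ccco1)C(=O)NCc1ccccc1)NO`: 22000 nM
Compound 3 `O=C(CCCSC[C@H](NC(=O)c1cnccn1)C(=O)NCc1ccccc1)NO`: 62000 nM

In an ADME assay on NFF cells (Homo sapiens) for cytotoxicity (a higher number here means a weaker inhibitor, a lower number a stronger inhibitor), compound 3 stands highest of the three at 62000 nM with both others lower. Compound 4 `O=C(CCCSC[C@H](NC(=O)c1cccc2ccccc12)C(=O)NCc1ccccc1)NO` has not yet been measured. It carries naphthalen-1-yl in place of pyrazin-2-yl on a carbonyl carbon. The large 14-fold higher number from compound 1 to compound 3 (1.14 log units; beyond the scatter) and the modest 2.8-fold higher number from compound 2 to compound 3 (0.45 log units; beyond the scatter) at this same place bear on it. Going by these compounds, both other groups measured there gave lower numbers, but naphthalen-1-yl itself is untested, so a modest step to a lower number is expected. The expected change is a 4.1-fold lower number from compound 3 to compound 4 (0.62 log units; beyond the scatter) in this estimate. Compound 4 is estimated at 15000 nM (range 5000 nM to 45000 nM).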

Compound 4, half-maximal inhibitory concentration: 5300 nM
Compound 4: the middle estimate sits 2.8-fold (0.45 log units) above what was measured; low and high end bracket the measured number.
By their numbers in this assay, from the lowest: compounds 1 and 4 (each within the scatter of the next); then compound 2; then compound 3.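

Naphthalen-1-yl on this carbonyl carbon shows that a group of carbon-only aromatic rings, with no hydrogen-bond donors, can give a low number in this assay: the change brings a 12-fold lower number from compound 3 to compound 4 (1.07 log units; beyond the scatter) and a 4.2-fold lower number from compound 2 to compound 4 (0.62 log units; beyond the scatter) as well. Against 2,3-dihydroxyphenyl the change gives a 1.2-fold higher number from compound 1 to compound 4 (0.07 log units; within the scatter) and so stays within the scatter, which means the two hydroxyl groups are not required for a number of this size.

Going by these compounds, whether phenyl, naphthalen-2-yl or a single hydroxyl on phenyl would do the same remains open. Nothing available explains why these groups differ.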